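From tert-butyl to iodo on the shared core

A few compounds are considered here, and "the series" means these few. Any claim that something is new, unique, unknown or untested is made for them only; others in the source may bear on it.

Measured compounds:
compound 1 `c1ccc(-c2ccc(NC3=NCCO3)cc2)cc1` gives 10600 nM
compound 2 `CC(C)(C)c1ccc(NC2=NCCO2)cc1` gives 3000 nM

Going by the values given here, in a functional assay on MCF7 cells (Homo sapiens) for inhibition, read by sulforhodamine B assay, with a stated time of 48 h (on this read-out higher numbers stand for weaker inhibition of growth and lower numbers for stronger inhibition of growth), compound 2 gives 3000 nM and holds the lower of the two numbers so far. Compound 3 `Ic1ccc(NC2=NCCO2)cc1` has not yet been measured and carries iodo in place of tert-butyl on an aromatic carbon, a change counted as iodo in place of tert-butyl on an aromatic carbon in its structure. Among the compounds with values here, one measured step bears on this carbon, tert-butyl in place of phenyl on an aromatic carbon. That step, a 3.5-fold lower number from compound 1 to compound 2 (0.55 log units; beyond the scatter) in this assay, was modest. Within the data shown here, it says nothing directly about iodo, which no measured compound carries, so no step beyond the scatter is expected and the direction stays open. The estimate means a 1.2-fold higher number from compound 2 to compound 3 (0.07 log units; within the scatter) as the expected step for this change. The estimated value of compound 3 is 3500 nM within an expected range of 1200 nM to 10000 nM for the coming measurement.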

Compound 3, concentration for 50% growth inhibition: 2900 nM
Beside the measured number, compound 3's estimate is 1.2-fold (0.08 log units) above it; the range from low to high includes it.
By their numbers in this assay, from the lowest: compounds 3 and 2 (each within the scatter of the next); then compound 1.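

In this assay, iodo in place of tert-butyl on the aromatic carbon gives a 1.0-fold lower number from compound 2 to compound 3 (0.01 log units; within the scatter) and so shows that one iodine atom can take the place of the four carbons of tert-butyl here with no step beyond the scatter. Iodo in place of phenyl gives a 3.7-fold lower number from compound 1 to compound 3 (0.56 log units; beyond the scatter) as a modest step of the same kind as the one seen with tert-butyl, so two different groups on this carbon now stand apart from phenyl. No measurement shown gives a reason for these results.

The compounds shown leave open whether an amine, a carboxylic acid or a methoxy group on this carbon would stay with iodo and tert-butyl or fall with phenyl. They also leave open what plain hydrogen at this place would give on the shared core.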